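A few compounds are considered here, and "the series" means these few. Any claim that something is new, unique, unknown or untested is made for them only; others in the source may bear on it.

Measured compounds: compound 1 `COc1cccc(Nc2nccc(-c3ccc(F)cc3)n2)c1`, > 1000 nM; compound 2 `Clc1ccc(Nc2nccc(-c3ccc(Br)cc3)n2)cc1`, 946 nM.

In an assay on isolated protein for inhibition of phosphatidylinositol 4,5-bisphosphate 3-kinase catalytic subunit beta isoform (Homo sapiens) (a lower number here means a stronger inhibitor, a higher number a weaker inhibitor), compound 1 is reported only as a limit of the assay, > 1000 nM, so it stands at the limit of > 1000 nM in this assay, at which 1 of the 2 values shown sits, rather than at a number. Compound 2 gives 946 nM in this assay. Compound 3 `COc1cccc(Nc2nccc(-c3ccc(Br)cc3)n2)c1` differs from compound 1 by bromo in place of fluoro on an aromatic carbon. Within the data shown here, with no measured step between compounds available, no step beyond the usual scatter is expected, the expected step being a step that the limit leaves unreadable from compound 1 to compound 3. Compound 3 is accordingly estimated at 1200 nM, between 400 nM and 4000 nM.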

Compound 3, half-maximal inhibitory concentration: 977 nM
Estimate against measurement, compound 3: 1.2-fold (0.09 log units) above; measured number inside the range.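

Putting bromo in place of fluoro on this aromatic carbon, para to a large group, gives an at least 1.0-fold lower number from compound 1 to compound 3 (0.01 log units; that floor lies within the scatter) in this assay, and compound 3 reads as a number, 977 nM. The true size of the change stays unknown, because compound 1 rests on a limit of the assay: the limit of > 1000 nM in this assay, at which 1 of the 3 values shown sits.

The compounds shown leave open whether fluoro and bromo truly differ here. They also leave open how an amine, a carboxylic acid or a longer chain on this carbon would behave in this assay.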